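A few compounds are considered here, and "the series" means these few. Any claim that something is new, unique, unknown or untested is made for them only; others in the source may bear on it.

Measured in a functional assay on RAW264.7 cells (Mus musculus) for inhibition, read by Griess assay, with stated times of 1 h and 24 h; a higher number here means a weaker inhibitor, a lower number a stronger inhibitor:
- compound 1 `CCCCCOc1ccccc1C1CC(=O)c2ccccc2O1`: 39200 nM
- compound 2 `O=C1CC(c2ccccc2OCc2ccccc2)Oc2ccccc21`: 18900 nM
- compound 3 `COCOc1ccccc1C1CC(=O)c2ccccc2O1`: 32600 nM

Compound 1 stands at the high end of these numbers. Methoxy in place of butyl gives a 1.2-fold lower number from compound 1 to compound 3 (0.08 log units; within the scatter), and phenyl in place of butyl gives a 2.1-fold lower number from compound 1 to compound 2 (0.32 log units; beyond the scatter). Compound 4 `CCOc1ccccc1C1CC(=O)c2ccccc2O1` differs from compound 1 by hydrogen in place of propyl on a saturated chain carbon, two bonds along the chain from an oxygen on an aromatic ring. These two steps bear on it, although neither makes this exact change. Both are small, so no change beyond the scatter is expected in this assay. The expected step is a 1.4-fold lower number from compound 1 to compound 4 (0.13 log units; within the scatter). Compound 4 is estimated at 29000 nM, with an expected range of 15000 nM to 55000 nM.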

Compound 4, half-maximal inhibitory concentration: 38500 nM
For compound 4 the middle estimate is 1.3-fold (0.12 log units) below the measured one, within the range that was stated.
By their numbers in this assay, from the lowest: compounds 2, 3, 4 and 1 (each within the scatter of the next, the first and the last beyond it).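

In this assay, cutting pentyloxy back to ethoxy gives a 1.0-fold lower number from compound 1 to compound 4 (0.01 log units; within the scatter), so at this place on the chain the loss of propyl moves the number by no more than the scatter. Methyl in place of methoxy gives a 1.2-fold higher number from compound 3 to compound 4 (0.07 log units; within the scatter), while methyl in place of phenyl gives a 2.0-fold higher number from compound 2 to compound 4 (0.31 log units; beyond the scatter), the only one of these steps beyond the scatter, and a modest one. Nothing available accounts for these steps.

As far as these compounds go, whether an amine or a carboxylic acid at the end of the chain would shift the number remains open. So does the effect of a chain longer than pentyloxy.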